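Removing the cyclopentyl group from compound 2

The source may report more compounds than this note shows. Statements on the series, on what has been measured and on what is new or still open speak of the compounds shown alone.

Compound 1 `COc1ccc(-c2noc(C3CCCN3)n2)cc1OC1CCCC1`: 19500 nM
Compound 2 `COc1ccc(-c2noc(-c3ccc(F)cc3)n2)cc1OC1CCCC1`: 6090 nM

In a functional assay on MIA PaCa-2 cells (Homo sapiens) for antiproliferative activity, read by MTT assay, with a stated time of 24 h (on this read-out lower numbers stand for stronger inhibition and higher numbers for weaker inhibition), compound 1 gives 19500 nM and compound 2 gives 6090 nM, the lower number of the two and so the stronger inhibition. The next compound to be tested is compound 3 `COc1ccc(-c2noc(-c3ccc(F)cc3)n2)cc1O`, which changes compound 2 in a single place: hydrogen in place of cyclopentyl on an oxygen on an aromatic ring. In words, cyclopentyloxy becomes hydroxy, with hydrogen in place of cyclopentyl on an oxygen on an aromatic ring.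

Among the measured compounds shown here, only one measured step is available as a guide: a 3.2-fold lower number from compound 1 to compound 2 (0.51 log units; beyond the scatter). That step swapped a different group, so it says nothing direct about this change and offers only a rough idea of how far one swap can move the number in this assay. With no direct test, the direction is a cautious judgement. A step of similar size is expected, towards weaker inhibition, and it could still fall within the scatter. The expected step is a 2.3-fold higher number from compound 2 to compound 3 (0.36 log units; beyond the scatter). For compound 3 the estimated value is 14000 nM, with an expected range from 4000 nM to 45000 nM.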

Compound 3, half-maximal inhibitory concentration: 351000 nM
Beside the measured number, compound 3's estimate is 25-fold (1.40 log units) below it; the measured number lies above the stated range.
By their numbers in this assay, from the lowest: compound 2; then compound 1; then compound 3.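

In this assay, the group on this oxygen turns out to matter a great deal: replacing cyclopentyl, with its 5 carbon atoms in one ring, by a lone hydrogen gives a 58-fold higher number from compound 2 to compound 3 (1.76 log units; beyond the scatter) and so a much weaker inhibition. Among the compounds shown here, this is a far larger move than a 3.2-fold lower number from compound 1 to compound 2 (0.51 log units; beyond the scatter), the only earlier step, which was made at a different place on the molecule. Within these three compounds, then, the cyclopentyl group on this oxygen has more effect on the number than the earlier swap of pyrrolidin-2-yl for 4-fluorophenyl, and no measurement offered here explains why the loss is so steep.

The compounds shown go straight from cyclopentyl to hydrogen, so they leave open how the number would respond to something in between on this oxygen, such as an ethyl group or a cyclopropylmethyl group, or to something larger, such as a benzyl group. They also leave open whether the same change would cost as much with pyrrolidin-2-yl in place of 4-fluorophenyl.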